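A Shorter Link to Sulfur on a Shared Core

The source may report more compounds than this note shows. Statements on the series, on what has been measured and on what is new or still open speak of the compounds shown alone.

Measured compounds:
compound 1, `Cc1cc(Nc2cc(-c3ccccc3)[nH]n2)n2nc(SCCCc3ccccc3)nc2n1`: in an ADME assay on GES1 cells (Homo sapiens) for inhibition, read by MTT assay, with a stated time of 72 h (a higher number here means a weaker inhibitor, a lower number a stronger inhibitor), compound 1 gives 40200 nM.
compound 2, `Cc1cc(Nc2ccn(Cc3cccc4ccccc34)n2)n2nc(SCc3ccc(Br)cc3)nc2n1`: in this assay compound 2 gives 30000 nM.
compound 3, `Cc1cc(Nc2cc(-c3ccccc3)[nH]n2)n2nc(SCc3ccc([N+](=O)[O-])cc3)nc2n1`: in this assay compound 3 gives 43600 nM.

Among these three numbers compound 1 stands second highest. Its nearest neighbour is compound 3, and the gap to compound 2 also lies within the scatter, so the three compounds cannot be placed in any order on this evidence.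

The unmeasured compound 4, `Cc1ccc(CSc2nc3nc(C)cc(Nc4cc(-c5ccccc5)[nH]n4)n3n2)cc1`, differs from compound 1 in one place: 4-methylphenyl in place of phenethyl on a saturated chain carbon bound to a sulfur. Among the measured compounds shown here, one measured step bears on this change, since it alters the group on the same saturated chain carbon bound to a sulfur: a 1.1-fold higher number from compound 1 to compound 3 (0.04 log units; within the scatter). Compound 2 differs from compound 1 in more than one place, so its value only shows that it sits close to the other two.

For the measured compounds named here, with the single bearing step staying within the scatter, and all three numbers clustered together, no step beyond the scatter is expected in this assay on going to compound 4. Compound 4 is therefore estimated at 40000 nM, within a range of 20000 nM to 80000 nM. For compound 4 the expected step is a 1.0-fold lower number from compound 1 to compound 4 (0.00 log units; within the scatter).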

Compound 4, half-maximal inhibitory concentration: 36200 nM
For compound 4 the middle estimate is 1.1-fold (0.04 log units) above the measured one; the measured number falls inside the stated range.
By their numbers in this assay, from the lowest: compounds 2, 4, 1 and 3 (each within the scatter of the next).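

Going from (3-phenylpropyl)sulfanyl to (4-methylbenzyl)sulfanyl leaves the number in this assay within the scatter (a 1.1-fold lower number from compound 1 to compound 4 (0.05 log units; within the scatter)), so 4-methylphenyl joins 4-nitrophenyl as a second group in place of phenethyl on a saturated chain carbon bound to a sulfur with no step beyond the scatter. Among the compounds shown here, compound 4 also adds a comparison that the earlier compounds could not give, between two substituents on the same aromatic carbon: methyl in place of nitro again stays within the scatter (a 1.2-fold lower number from compound 3 to compound 4 (0.08 log units; within the scatter)). Nothing measured here speaks to why these numbers stay together.

The compounds shown leave open whether an amine or a carboxylic acid in place of methyl or nitro on that aromatic carbon, or a longer chain on the sulfur, would bring a step beyond the scatter in this assay. They also leave open whether the same flat result would hold with a different group on the shared core, since compound 2 differs from these compounds in more than one place and cannot be compared with them step by step.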